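Trading the oxolane for a methyl on a shared core

The compounds below may be only part of what the source reports. "The series", "measured", "known", "first", "only" and "open" are said of these compounds alone.

Compound 1 `Cc1cc(C)c(CN2CCc3c(Cl)cc([C@@H](CO)[C@@H]4CCOC4)c(Cl)c3C2=O)c(=O)[nH]1` is measured in an assay on cells for inhibition of histone-lysine N-methyltransferase EZH2 (Homo sapiens), read by ELISA, with a stated time of 72 h (a lower number here means a stronger inhibitor, a higher number a weaker inhibitor), and gives 2910 nM, the highest single number among everything shown here. Its two relatives carry several entries each: compound 2 `COC(c1cc(Cl)c2c(c1Cl)C(=O)N(Cc1c(C)cc(C)[nH]c1=O)CC2)C1CCOC1` gives 1100 nM; 494 nM; 47 nM; 7 nM (4 entries) in this assay, and compound 3 `Cc1cc(C)c(CN2CCc3c(Cl)cc(C(CO)C4CCOC4)c(Cl)c3C2=O)c(=O)[nH]1` gives 1010 nM; 15 nM (2 entries). The spread within those entries, seen in the several entries of compound 2 in this assay, 1100 nM; 494 nM; 47 nM; 7 nM (4 entries) and (the several entries of compound 3 in this assay, 1010 nM; 15 nM (2 entries)), is far wider than the usual scatter, so the picture around compound 1 is uncertain. Compound 1 and compound 3 share every atom and differ only in that (the fact that one of compounds 1 and 3 is drawn with a defined configuration and the other without, at the place where they differ).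

Compound 4 `Cc1cc(C)c(CN2CCc3c(Cl)cc([C@H](C)CO)c(Cl)c3C2=O)c(=O)[nH]1` has not yet been measured in this assay. It differs from compound 1 in one place: methyl in place of oxolan-3-yl on a saturated chain carbon bound to an aromatic carbon and a saturated chain carbon. The defined stereocentre is kept, so compound 4 is a single isomer like compound 1.

Among the compounds with values here, with no measured step of this kind available, the step from compound 1 to compound 4 is expected to be modest, most likely toward a somewhat lower number, but it could fall either way beyond the scatter. The estimate for compound 4 in this assay is 900 nM, within 70 nM to 9000 nM, which corresponds to an expected step of a 3.2-fold lower number from compound 1 to compound 4 (0.51 log units; beyond the scatter).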

Compound 4, half-maximal inhibitory concentration: 129 nM
The estimate for compound 4 lay 7.0-fold (0.84 log units) above the measured number; measured number inside the range.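

In this assay, within the data shown here, this is the first step that can be read at this position: a 23-fold lower number from compound 1 to compound 4 (1.35 log units; beyond the scatter). It shows that the oxolan-3-yl is not needed on this saturated chain carbon bound to an aromatic carbon and a saturated chain carbon for a lower number, and that methyl, with no ring and no hydrogen-bond acceptor, goes with the stronger inhibitor of this pair. The size of the step is less firm than its direction suggests, because it starts from the single number of compound 1, while the entries for the compound with the same atoms spread far beyond the usual scatter: the several entries of compound 3 in this assay, 1010 nM; 15 nM (2 entries)

The compounds shown leave open whether the higher number of compound 1 goes with the ring itself or with its oxygen, a question that a cyclopentyl or an ethyl at this place would help to separate. Also open is how much the configuration at this place bears on the number, since the pair that could speak to it differs only in how it is drawn: the fact that one of compounds 1 and 3 is drawn with a defined configuration and the other without, at the place where they differ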